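Replacing the acetyl on compound 3 with a 2-methoxyphenyl

The source may report more compounds than this note shows. Statements on the series, on what has been measured and on what is new or still open speak of the compounds shown alone.

Measured compounds:
compound 1 `O=C(Nc1ccc2nc(NC(=O)C3CCCCC3)sc2c1)c1ccccc1F`, 0.14 ug/mL;
compound 2 `O=C(Nc1ccc2nc(NC(=O)C3CCCCC3)sc2c1)c1ccccc1Oc1ccccc1`, 0.1 ug/mL;
compound 3 `CC(=O)Nc1nc2ccc(NC(=O)c3c(Cl)cccc3Cl)cc2s1`, 0.6 ug/mL.

Of the compounds shown here, three sharing one core have been measured in a functional assay on WI-38 VA13 cells (Homo sapiens) for cytotoxicity; on this read-out higher numbers stand for an effect only at larger amounts of compound and lower numbers for an effect already at smaller amounts. Among the compounds with values here, compound 1 gives 0.14 ug/mL, and the only single-point step among them, a 1.4-fold lower number from compound 1 to compound 2 (0.15 log units; within the scatter), leaves the number essentially unchanged. Compound 3 stands highest of the three numbers; its nearest neighbour is compound 1 at a gap beyond the scatter, and compound 2 lies further still.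

Compound 4 `COc1ccccc1Nc1nc2ccc(NC(=O)c3c(Cl)cccc3Cl)cc2s1` is not yet measured. It differs from compound 3 in one place: 2-methoxyphenyl in place of acetyl on a nitrogen on an aromatic ring. Within the data shown here, no measured step concerns this nitrogen, since compounds 1 and 2 carry a different group there and also differ from compound 3 elsewhere; the one measured step touches the other side of the molecule and was within the scatter. With nothing to guide the direction, compound 4 is expected to stay close to compound 3, so the step of a 1.3-fold lower number from compound 3 to compound 4 (0.12 log units; within the scatter) is expected to be small. Compound 4 is therefore estimated at 0.45 ug/mL, with a range from 0.1 ug/mL to 2 ug/mL.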

Compound 4, half-maximal effective concentration: > 7.2 ug/mL
Compound 4: no number, only a limit (the forecaster's own chance of this, stated with the estimate: 5%); middle value at least 16-fold (1.20 log units) from the limit.
By their numbers in this assay, from the lowest: compounds 2 and 1 (each within the scatter of the next); then compound 3. At a limit, above all of these: compound 4.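

The exchange of acetyl for 2-methoxyphenyl on a nitrogen on an aromatic ring gives, in this assay, an at least 12-fold higher number from compound 3 to compound 4 (1.07 log units; beyond the scatter), so this position moves the read-out far more than the exchange of fluoro for phenoxy did, a 1.4-fold lower number from compound 1 to compound 2 (0.15 log units; within the scatter). Compound 4 gives no number here, only a limit of the assay, the sole such entry among the compounds shown: the limit of > 7.2 ug/mL in this assay, at which 1 of the 4 values shown sits. With acetamido at this place, compound 3 acts at smaller amounts than compound 4 with (2-methoxyphenyl)amino, a contrast that compound 1 and compound 2 could not show, since they carry one and the same group on that nitrogen.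

From the compounds shown here alone, it remains open whether the carbonyl leaving or the aromatic ring entering carries this step. A benzoyl or an unsubstituted phenyl on that nitrogen would tell these apart and would also bear on the part played by the methoxy.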